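The source may report more compounds than this note shows. Statements on the series, on what has been measured and on what is new or still open speak of the compounds shown alone.

In a functional assay on K562 cells (Homo sapiens) for cytotoxicity, read by MTT assay, with a stated time of 24 h (a higher number here means a weaker inhibitor, a lower number a stronger inhibitor), compound 2 `COc1cc(/C=C2\CN(C)C/C(=C\c3ccc(F)cc3)C2=O)cc(OC)c1` gives 11300 nM, the highest of the three numbers measured. Compound 1 `COc1cc(/C=C2\CN(C)C/C(=C\c3ccccc3F)C2=O)cc(OC)c1OC` gives 4340 nM and compound 3 `COc1cc(/C=C2\CN(C)C/C(=C\c3ccc(C#N)cc3)C2=O)cc(OC)c1` gives 4650 nM. Compound 4 `COc1cc(/C=C2\CN(C)C/C(=C\c3ccc(F)cc3)C2=O)cc(OC)c1OC` alters compound 2 in one place: methoxy in place of hydrogen on an aromatic carbon. Among the compounds with values here, the only measured single change, a 2.4-fold lower number from compound 2 to compound 3 (0.39 log units; beyond the scatter), was modest and concerns a different aromatic ring, so it bears only indirectly. Compound 1 already carries this methoxy, with its fluoro placed differently, and reads 4340 nM. A modest fall in this assay is therefore expected. The estimated value for compound 4 is 5200 nM, within a range of 2500 nM to 11500 nM. This expectation amounts to a 2.2-fold lower number from compound 2 to compound 4 (0.34 log units; beyond the scatter).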

Compound 4, half-maximal inhibitory concentration: 10300 nM
Estimate against measurement, compound 4: 2.0-fold (0.30 log units) below; the range from low to high includes it.
By their numbers in this assay, from the lowest: compounds 1 and 3 (each within the scatter of the next); then compounds 4 and 2 (each within the scatter of the next).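

In this assay, adding methoxy to the aromatic carbon ortho to two methoxy groups gives a 1.1-fold lower number from compound 2 to compound 4 (0.04 log units; within the scatter) and so makes no readable difference, at least with 4-fluorophenyl on the other side of the shared core. The fluoro placement matters more here, since 4-fluorophenyl in place of 2-fluorophenyl gives a 2.4-fold higher number from compound 1 to compound 4 (0.38 log units; beyond the scatter) as a modest step. No evidence is available to explain either step.

Going by these compounds, whether an amine or a longer ethoxy chain at this position would read differently stays open. Also open, on these data alone, is whether 2-fluorophenyl would keep its advantage without this methoxy.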